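The source may report more compounds than this note shows. Statements on the series, on what has been measured and on what is new or still open speak of the compounds shown alone.

Measured so far:
- Compound 1, `Oc1nnc(-c2cccnc2)c2ccccc12`, gives 26% in an assay on isolated protein (Oryctolagus cuniculus) with Thromboxane-A synthase (Homo sapiens) as the target, tested at 1 uM; on this read-out higher numbers stand for more inhibition at the one concentration tested (going by the name of the read-out) and lower numbers for less inhibition.
- Compound 2, `O=c1c2ccccc2c(-c2cccnc2)nn1CC1CCCCC1`, gives 98% in this assay.
- Compound 3, `O=c1c2ccccc2c(-c2cccnc2)nn1CCCCSc1ncccn1`, gives 96% in this assay.

Compound 2 stands at the top end of these three numbers, but compound 3 lies within the usual scatter of it, so the two cannot be told apart. Both stand far above compound 1, which carries no group on the ring nitrogen and gives a far lower number here.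

Compound 4, `O=C(O)c1ccc(Cn2nc(-c3cccnc3)c3ccccc3c2=O)cc1`, has not yet been measured in this assay. It differs from compound 2 in one place: 4-carboxyphenyl in place of cyclohexyl on a saturated chain carbon bound to an aromatic nitrogen. In the two measured compounds that carry a group on that nitrogen, a cyclohexyl and a longer chain ending in a ring give numbers within the scatter of each other, so the inhibition in this assay is level between those two groups there. A carboxylic acid on an aromatic ring is a new feature, and nothing measured shows how it behaves. A step from compound 2 to compound 4 of no more than a small loss, possibly none beyond the scatter, is expected, with room for a larger drop. Compound 4 is estimated at 85%, between 55% and 99%, meaning an expected step of a number 13 percentage points lower from compound 2 to compound 4 (beyond the scatter).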

Compound 4, a percentage reported as inhibition, at one concentration (the size of the read-out at that concentration, not a potency): 64%
For compound 4 the middle estimate is 21 percentage points above the measured one; measured number inside the range.
By their numbers in this assay, from the lowest: compound 1; then compound 4; then compounds 3 and 2 (each within the scatter of the next).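

Replacing cyclohexyl with 4-carboxyphenyl on a saturated chain carbon bound to an aromatic nitrogen gives, in this assay, a number 34 percentage points lower from compound 2 to compound 4 (beyond the scatter), so the number at this position does depend on the group placed there. The level numbers of compound 2 and compound 3 could not show this, since those two groups, a cyclohexyl and a longer chain ending in a ring, cannot be told apart here. The change lowers the inhibition without removing it, as compound 4 still gives 64% at the one concentration tested, and no available information bears on why the number falls.

This single change brings in an aromatic ring and a carboxylic acid together, and the compounds shown cannot say which of the two goes with the lower number. A plain phenyl on the same carbon would separate these two features, while a carboxylic acid at the end of a longer chain would show whether the acid gives the same step when it sits on a chain instead of an aromatic ring.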